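Oxazoline in place of nitrile on the shared core

The compounds below may be only part of what the source reports. "The series", "measured", "known", "first", "only" and "open" are said of these compounds alone.

Compound 3 `N#Cc1cc(-c2ccoc2)c2ccc(OCc3cccc(C4(O)CCOCC4)c3)cc2c1` stands lowest of the three numbers recorded in an assay on isolated protein with Polyunsaturated fatty acid 5-lipoxygenase (Homo sapiens) as the target (a higher number here means a weaker inhibitor, a lower number a stronger inhibitor), at 30 nM. Compound 2 `N#Cc1cc(-c2ccccc2)c2ccc(OCc3cccc(C4(O)CCOCC4)c3)cc2c1` gives 120 nM in this assay, and compound 1 `COC(C)c1cc(-c2ccccc2)c2ccc(OCc3cccc(C4(O)CCOCC4)c3)cc2c1` gives 1200 nM. Both recorded steps are beyond the scatter: a 10-fold lower number from compound 1 to compound 2 (1.00 log units; beyond the scatter) and a 4.0-fold lower number from compound 2 to compound 3 (0.60 log units; beyond the scatter).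

Compound 4 `CC1(C)COC(c2cc(-c3ccoc3)c3ccc(OCc4cccc(C5(O)CCOCC5)c4)cc3c2)=N1` differs from compound 3 by a group of 7 heavy atoms (5 carbon, 1 nitrogen, 1 oxygen; one five-membered non-aromatic ring with 2 hetero atoms) in place of a group of 2 heavy atoms (1 carbon, 1 nitrogen; no ring), on an aromatic carbon. Of the two measured steps, only a 10-fold lower number from compound 1 to compound 2 (1.00 log units; beyond the scatter) concerns this position; there, the cyano group was the better of the two groups tried, and the number moved by a modest amount. The step of a 4.0-fold lower number from compound 2 to compound 3 (0.60 log units; beyond the scatter) changes a different place and bears only indirectly. The position therefore tolerates change on the scale seen, but the group now removed is the one that gave the gain, so a modest move upward in this assay is expected, a 2.7-fold higher number from compound 3 to compound 4 (0.43 log units; beyond the scatter). Compound 4 is estimated at 80 nM, with a range from 25 nM to 300 nM.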

Compound 4, half-maximal inhibitory concentration: 190 nM
Beside the measured number, compound 4's estimate is 2.4-fold (0.38 log units) below it; measured number inside the range.
By their numbers in this assay, from the lowest: compound 3; then compounds 2 and 4 (each within the scatter of the next); then compound 1.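

In this assay, oxazoline in place of nitrile on this aromatic carbon gives a 6.3-fold higher number from compound 3 to compound 4 (0.80 log units; beyond the scatter) with the furan-3-yl group held constant. The nitrile therefore stays ahead of a second, quite different replacement, whereas the earlier comparison at this position covered only the 1-methoxyethyl group on a phenyl-bearing compound. The step is modest, so a group of 7 heavy atoms with a five-membered non-aromatic ring still leaves measurable inhibition at this position. Nothing available here accounts for the size of this step.

Going by these compounds, whether the nitrile keeps the same lead over the oxazoline with phenyl in place of furan-3-yl remains open. Also open, on these data alone, is how a carboxylic acid, a primary amide or an amine on this aromatic carbon would compare with the nitrile.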